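Adding a Dichlorophenyl Group to Compound 2

The compounds below may be only part of what the source reports. "The series", "measured", "known", "first", "only" and "open" are said of these compounds alone.

Compound 1 `Cc1ccc2[nH]c(-n3[nH]c(C)c(Cc4ccc(C(F)(F)F)cc4)c3=O)nc2c1`: 570 nM
Compound 2 `Cc1ccc2[nH]c(-n3[nH]c(C)c(C)c3=O)nc2c1`: 2600 nM
Compound 3 `O=c1c(Cc2ccccc2)c(-c2ccccc2)[nH]n1-c1nc2ccccc2[nH]1`: > 10000 nM

In an assay on isolated protein for inhibition of alpha-ketoglutarate-dependent dioxygenase alkB homolog 3 (Homo sapiens), read by polymerase chain reaction, with a stated time of 1 h (on this read-out higher numbers stand for weaker inhibition and lower numbers for stronger inhibition), compound 2 gives 2600 nM, the highest of the two numbers shown. Compound 1 gives 570 nM, a lower number, and that gap lies beyond the usual scatter. Compound 3 reaches only a limit of the assay, > 10000 nM, as stated in the limit of > 10000 nM in this assay, at which 1 of the 3 values shown sits.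

Compound 4 `Cc1ccc2[nH]c(-n3[nH]c(C)c(Cc4ccc(Cl)c(Cl)c4)c3=O)nc2c1` has not been measured. It differs from compound 2 by 3,4-dichlorophenyl in place of hydrogen on a saturated chain carbon bound to an aromatic carbon. Compound 1 also carries a group at that same place and gives 570 nM, so compound 4 is expected to move in the same direction, toward stronger inhibition, by a 5.2-fold lower number from compound 2 to compound 4 (0.72 log units; beyond the scatter). In this assay compound 4 is estimated at 500 nM, within a range from 150 nM to 1700 nM.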

Compound 4, half-maximal inhibitory concentration: 720 nM
The estimate for compound 4 lay 1.4-fold (0.16 log units) below the measured number, and the stated range covers the measured number.
By their numbers in this assay, from the lowest: compounds 1 and 4 (each within the scatter of the next); then compound 2. At a limit, above all of these: compound 3.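

Placing 3,4-dichlorophenyl on the saturated chain carbon gives a 3.6-fold lower number from compound 2 to compound 4 (0.56 log units; beyond the scatter), so the gain at this place is now seen with a second ring and not only with the one in compound 1. Compound 1 and compound 4 lie within the usual scatter of each other, so the gain is not tied to the trifluoromethyl group. As far as these compounds go, whether a ring carrying an amine or a carboxylic acid would keep this gain stays open. Nothing shown here explains why the step occurs.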